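Replacing the dichlorophenyl of compound 3 with a hydroxyphenyl

The compounds below may be only part of what the source reports. "The series", "measured", "known", "first", "only" and "open" are said of these compounds alone.

Three compounds share one core and differ only in the aryl group on a carbon with a double bond to nitrogen. In a functional assay on NCI-H460 cells (Homo sapiens) for cytotoxicity, read by MTT assay, with a stated time of 72 h (a higher number here means a weaker inhibitor, a lower number a stronger inhibitor), compound 3 `CN(C)CCn1cnnc1-c1cc(Oc2ccc(NC(=O)N/N=C/c3cccc(Cl)c3Cl)cc2F)ccn1` gives 72 nM, the lowest of the three numbers; compound 1 `CN(C)CCn1cnnc1-c1cc(Oc2ccc(NC(=O)N/N=C/c3ccc(O)c(Br)c3)cc2F)ccn1` gives 430 nM and compound 2 `CN(C)CCn1cnnc1-c1cc(Oc2ccc(NC(=O)N/N=C/c3ccc(F)cc3F)cc2F)ccn1` gives 1930 nM. The steps are a 6.0-fold lower number from compound 1 to compound 3 (0.78 log units; beyond the scatter), a 4.5-fold higher number from compound 1 to compound 2 (0.65 log units; beyond the scatter) and a 27-fold lower number from compound 2 to compound 3 (1.43 log units; beyond the scatter). Compound 4 `CN(C)CCn1cnnc1-c1cc(Oc2ccc(NC(=O)N/N=C/c3ccc(O)cc3)cc2F)ccn1` carries 4-hydroxyphenyl in place of 2,3-dichlorophenyl on a carbon with a double bond to nitrogen. The step from compound 1 to compound 3 bears most closely on this change, since compound 1 also carries a hydroxyphenyl, and it went in the opposite direction; compound 4 is therefore expected to show a higher number than compound 3, about an 8.3-fold higher number from compound 3 to compound 4 (0.92 log units; beyond the scatter). In this assay compound 4 is estimated at 600 nM, within a range of 200 nM to 1800 nM.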

Compound 4, half-maximal inhibitory concentration: 1780 nM
The estimate for compound 4 lay 3.0-fold (0.47 log units) below the measured number, and the stated range covers the measured number.
By their numbers in this assay, from the lowest: compound 3; then compound 1; then compounds 4 and 2 (each within the scatter of the next).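

In this assay, a 25-fold higher number from compound 3 to compound 4 (1.39 log units; beyond the scatter), so the 4-hydroxyphenyl group does not hold the level of the 2,3-dichlorophenyl group at this carbon. The 4-hydroxyphenyl and 2,4-difluorophenyl groups cannot be told apart here, with a 1.1-fold lower number from compound 2 to compound 4 (0.04 log units; within the scatter), so two quite different aryl groups now share one level. The bromo group also counts on the hydroxyphenyl ring, with a 4.1-fold higher number from compound 1 to compound 4 (0.62 log units; beyond the scatter) when hydrogen takes its place. On these data alone, how a 4-methoxyphenyl or 2,3-dimethylphenyl group would stand at this carbon remains open, and with it whether the chlorines of compound 3 are needed for its low number. Nothing available explains these differences.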